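The source may report more compounds than this note shows. Statements on the series, on what has been measured and on what is new or still open speak of the compounds shown alone.

Measured so far:
- Compound 1, `CN(C)C(=O)[C@H]1CCC[C@@H](c2cccc(-n3ncc(C(=O)O)c3C3CC3)c2)C1`: 1.7
- Compound 2, `O=C(O)c1cnn(-c2cccc(-c3cccc(C(=O)N(CC4CC4)CC4CC4)c3F)c2)c1C1CC1`: 3.5
- Compound 3, `CCCC1CCCCN1C(=O)C1CCCC(c2cccc(-n3ncc(C(=O)O)c3C3CC3)c2)C1`: 4.1

These three compounds share a core that carries a carboxylic acid and a cyclopropyl group, and differ in the amide group attached to a carbonyl carbon. In a physicochemical assay for lipophilicity, read by HPLC, at pH 2 (a higher number here means a more lipophilic compound, a lower number a more polar compound), compound 1 gives 1.7, compound 2 gives 3.5 and compound 3 gives 4.1. Compound 2 stands second highest of the three: its nearest neighbour is compound 3, whose number is higher by an amount beyond the usual scatter, and the furthest is compound 1, whose number is lower by a wide margin.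

Compound 4, `O=C(O)c1cnn(-c2cccc(-c3cccc(C(=O)N4CCCC5(CCCC5)C4)c3F)c2)c1C1CC1`, is not yet measured in this assay. It differs from compound 2 in one place:
a group of 10 heavy atoms (9 carbon, 1 nitrogen; one five-membered non-aromatic ring of carbon only, one six-membered non-aromatic ring with 1 hetero atom) in place of a group of 9 heavy atoms (8 carbon, 1 nitrogen; 2 three-membered non-aromatic rings of carbon only), on a carbonyl carbon
The group that enters has one more heavy atom than the one that leaves, and neither carries a hydrogen-bond donor or acceptor or a charge. Among the compounds with values here, no measured pair shows this exact change, so the step can only be expected, not read off. A small rise in this assay, at most at the edge of the scatter, seems the most likely outcome, with no change beyond the scatter also plausible. Compound 4 is therefore expected to give 3.7 in this assay, within a range of 3.3 to 4.1, which means an expected step of a number 0.20 log units higher from compound 2 to compound 4 (within the scatter).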

Compound 4, distribution coefficient: 3.7
The estimate for compound 4 equals the measured number at the digits printed, and the stated range covers the measured number.
By their numbers in this assay, from the lowest: compound 1; then compounds 2 and 4 (each within the scatter of the next); then compound 3.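

Within the data shown here, this pair gives the first direct reading of a single change on a carbonyl carbon whose other neighbours are: aromatic carbon, since the earlier compounds differ from one another in more than one place. In this assay, putting the group of 10 heavy atoms, with its one five-membered ring of carbon only and one six-membered ring with 1 hetero atom, in place of bis(cyclopropylmethyl)amino gives a step of a number 0.20 log units higher from compound 2 to compound 4 (within the scatter). So at this position, two differently built groups, both without hydrogen-bond donors, acceptors or net charge, are not told apart by this measurement, and no supporting measurement is available to explain that.

This single step says nothing about how the number would respond at the same place to a group that does carry hetero atoms beyond the amide nitrogen, such as morpholine or piperazine, or to a simple open chain such as diethylamino. Whether such groups would give a step beyond the scatter, and whether the close match seen here holds for other pairs, remains open.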